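Swapping the chain end for chloro on an aryl sulfonate amide

The source may report more compounds than this note shows. Statements on the series, on what has been measured and on what is new or still open speak of the compounds shown alone.

Measured so far:
- compound 1, `CCC(=O)Nc1cccc(S(=O)(=O)Oc2ccccc2C(C)C)c1`: 14000 nM
- compound 2, `CCCCCC(=O)Nc1ccc(S(=O)(=O)Oc2ccccc2C(C)C)cc1`: 5300 nM
- compound 3, `CCCCCC(=O)Nc1ccc(S(=O)(=O)Oc2ccccc2I)cc1`: 10000 nM

All three compounds were tested in a functional assay on MCF7 cells (Homo sapiens) for antiproliferative activity, read by sulforhodamine B assay, with a stated time of 48 h; a higher number here means a weaker inhibitor, a lower number a stronger inhibitor. Compound 3 sits among the three with nothing beyond the scatter around it: compound 1 lies within the scatter of it, and compound 2 lies within the scatter as well. Among the compounds with values here, the one single-point step among the measured compounds, a 1.9-fold higher number from compound 2 to compound 3 (0.28 log units; within the scatter), concerns the group on the aromatic carbon, not the chain on the amide.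

Compound 4, `O=C(CCCCl)Nc1ccc(S(=O)(=O)Oc2ccccc2I)cc1`, differs from compound 3 in the amide chain only: chloro in place of ethyl on a saturated chain carbon, three bonds along the chain from a carbonyl carbon. Cut one bond further out, the same difference reads pentyl to 3-chloropropyl. Within the data shown here, no measured step touches the amide chain, and compound 1 and compound 2 differ in more than one place, so their two values give no clean guide. In the absence of a relevant step, no change beyond the scatter is expected, and the step of no change at the digits printed from compound 3 to compound 4 (within the scatter) is an estimate of that. Compound 4 is therefore expected to give about 10000 nM in this assay, with a range from 4000 nM to 25000 nM.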

Compound 4, half-maximal inhibitory concentration: 6300 nM
Compound 4: the middle estimate sits 1.6-fold (0.20 log units) above what was measured; the measured number falls inside the stated range.
By their numbers in this assay, from the lowest: compounds 2, 4, 3 and 1 (each within the scatter of the next, the first and the last beyond it).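

In this assay, the amide chain now has a measured step of its own: a 1.6-fold lower number from compound 3 to compound 4 (0.20 log units; within the scatter), with chloro in place of ethyl on a saturated chain carbon, three bonds along the chain from a carbonyl carbon. At this position, then, pentyl and 3-chloropropyl cannot be told apart in this read-out, at least with the iodo group kept on the aromatic carbon. No measurement at hand offers an explanation for this result.

From the compounds shown here alone, whether an amine, a carboxylic acid or a longer chain at the same position would move the number beyond the scatter stays open. Going by these compounds, it is also open whether the same swap would give a similar step with isopropyl in place of iodo on the aromatic carbon.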